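Side-chain variation on the anilide of a shared triaryl core

A few compounds are considered here, and "the series" means these few. Any claim that something is new, unique, unknown or untested is made for them only; others in the source may bear on it.

Measured compounds:
compound 1 `Cn1c(-c2ccc(NC(=O)CCl)cc2)nc(-c2ccccc2)c1-c1ccccc1` — 23.7%
compound 2 `Cn1ccnc1SCC(=O)Nc1ccc(-c2nc(-c3ccccc3)c(-c3ccccc3)n2C)cc1` — 36.5%

In a functional assay on HT-29 cells (Homo sapiens) for cytotoxicity, read by MTT assay, with a stated time of 24 h, tested at 16 ug/mL (a higher number here means a stronger effect of the compound at the concentration tested, a lower number a weaker effect), compound 1 gives 23.7% and compound 2 gives 36.5%. Among the compounds with values here, the single measured step, a number 12.8 percentage points higher from compound 1 to compound 2 (beyond the scatter), puts compound 2 highest of the two numbers, with compound 1 the nearest number and lower beyond the scatter.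

Compound 3 `CN(C)/C=C/N1CCN(CC(=O)Nc2ccc(-c3nc(-c4ccccc4)c(-c4ccccc4)n3C)cc2)CC1` keeps the shared core of compound 2 and changes the group on the saturated chain carbon bound to the carbonyl carbon: 4-(2-(dimethylamino)ethenyl)piperazin-1-yl in place of (1-methyl-1H-imidazol-2-yl)sulfanyl on a saturated chain carbon bound to a carbonyl carbon.

Within the data shown here, only one step bears on this position, a number 12.8 percentage points higher from compound 1 to compound 2 (beyond the scatter), and it describes the move from chloro to the group that now leaves, not to the group that enters. Among the measured compounds shown here, no measured pair shows the effect of 4-(2-(dimethylamino)ethenyl)piperazin-1-yl, so the size and direction of the coming step rest on nothing firmer than the modest spread seen so far. The expectation is therefore a step of about a number 1.5 percentage points lower from compound 2 to compound 3 (within the scatter), within the scatter, with wide uncertainty either way. Compound 3 is estimated to give 35% in this assay, with a range from 15% to 60%.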

Compound 3, a percentage reported as activity, at one concentration (the size of the read-out at that concentration, not a potency): 28.2%
Estimate against measurement, compound 3: 6.8 percentage points above; the range from low to high includes it.
By their numbers in this assay, from the lowest: compounds 1, 3 and 2 (each within the scatter of the next, the first and the last beyond it).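

In this assay the new side chain gives a number 8.3 percentage points lower from compound 2 to compound 3 (within the scatter) and a number 4.5 percentage points higher from compound 1 to compound 3 (within the scatter) on the same scale, so 4-(2-(dimethylamino)ethenyl)piperazin-1-yl cannot be told apart from either (1-methyl-1H-imidazol-2-yl)sulfanyl or chloro on a saturated chain carbon bound to a carbonyl carbon. Within the data shown here, the only step here beyond the scatter remains a number 12.8 percentage points higher from compound 1 to compound 2 (beyond the scatter) and compound 3 does not sharpen it, so a non-aromatic six-membered ring with more heavy atoms can stand in place of the five-membered aromatic ring without a step beyond the scatter from compound 2. Nothing at hand explains these numbers.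

Still open, on these data alone, is whether a simpler amine, such as morpholin-4-yl or piperazin-1-yl without the 2-(dimethylamino)ethenyl group, would separate from compound 2 or compound 1 by more than the scatter. Also open is what a carboxylic acid or a longer chain would do at this place, and whether the small differences among these three compounds would hold up as differences in potency, since the read-out comes from a single concentration.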